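The source may hold more compounds than are shown below. What is called first, only, known or untested is meant among the compounds shown, and "the series" means these compounds.

Compound 2 `O=C(Nc1ccc(NCc2ccc(Cl)cc2)cc1Cl)c1cc(Cl)ccc1O` was run in an ADME assay on A549 cells (Homo sapiens) for cytotoxicity, read by resazurin assay, with a stated time of 48 h (a higher number here means that more compound is tolerated, a lower number that less compound is tolerated), where compound 2 gives 59700 nM. Compound 1 `CC(C)CNc1ccc(NC(=O)c2cc(Cl)ccc2O)c(Cl)c1` gives 60000 nM in the same assay, and the two numbers lie within the scatter of each other, so neither compound can be set apart from the other. Among the measured compounds shown here, the single step joining them, a 1.0-fold lower number from compound 1 to compound 2 (0.00 log units; within the scatter), shows that exchanging the group on the amine-bearing carbon left the number unmoved.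

Compound 3 `O=C(Nc1ccc(NCc2ccc(O)cc2)cc1Cl)c1cc(Cl)ccc1O` has not yet been measured. It differs from compound 2 by hydroxy in place of chloro on an aromatic carbon. For the measured compounds named here, no measured step exchanges a chloro for a hydroxy, so the earlier step bears on it only loosely: it shows that altering the (4-chlorobenzyl)amino part did not shift the number. Compound 3 is therefore expected to sit close to compound 2, with a 1.1-fold lower number from compound 2 to compound 3 (0.04 log units; within the scatter). The estimate for compound 3 is 55000 nM, within a range from 25000 nM to 120000 nM.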

Compound 3, half-maximal cytotoxic concentration: 116000 nM
Estimate against measurement, compound 3: 2.1-fold (0.32 log units) below, within the range that was stated.
By their numbers in this assay, from the lowest: compounds 2, 1 and 3 (each within the scatter of the next).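

In this assay, among the compounds shown here, the step of a 1.9-fold higher number from compound 2 to compound 3 (0.29 log units; within the scatter) gives the first reading of a change on the aromatic ring of the 4-chlorobenzyl group itself: with hydroxy in place of chloro, para to a large group, the number stays within the scatter. The step of a 1.9-fold higher number from compound 1 to compound 3 (0.29 log units; within the scatter) is also within the scatter, so compounds 1, 2 and 3, carrying isopropyl, 4-chlorophenyl and 4-hydroxyphenyl on the saturated chain carbon, cannot be set apart here. No measured evidence on these compounds speaks to this result.

From the compounds shown here alone, whether a methoxy, an amine or a carboxylic acid at the same ring position would also stay within the scatter remains open. Equally open, going by these compounds, is how this assay responds to a change in the shared core rather than in this side chain.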